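Trifluoromethoxy for trifluoromethyl in compound 3

The source may report more compounds than this note shows. Statements on the series, on what has been measured and on what is new or still open speak of the compounds shown alone.

In an ADME assay on HS27 cells (Homo sapiens) for antiproliferative activity, read by sulforhodamine B assay, with a stated time of 48 h (on this read-out higher numbers stand for weaker inhibition and lower numbers for stronger inhibition), compound 1 (`O=C(O)c1cc2cc(-c3ccc(F)cc3)ccc2n1O`) gives > 100000 nM as a limit of the assay, not a number. Compound 2 (`COc1ccc(-c2ccc3c(c2)cc(C(=O)O)n3O)cc1`) gives > 100000 nM as a limit too. Within the data shown here, the one measured step is a step that the two limits leave unreadable from compound 1 to compound 2 and it offers no size to carry forward. Compound 3 (`O=C(O)c1cc2ccc(-c3ccc(C(F)(F)F)cc3)cc2n1O`) stands at 68000 nM in this assay. It holds the only number shown, the other two values being limits.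

In compound 4 (`O=C(O)c1cc2ccc(-c3ccc(OC(F)(F)F)cc3)cc2n1O`) trifluoromethoxy takes the place of trifluoromethyl on an aromatic carbon, para to a large group (trifluoromethoxy in place of trifluoromethyl on an aromatic carbon). Among the measured compounds shown here, no measured step covers this exchange. Compound 1 and compound 2 share the limit of > 100000 nM in this assay, at which 2 of the 3 values shown sit, and that leaves a limit reading possible for compound 4 as well. For the measured compounds named here, the expectation therefore stays anchored on compound 3 at 68000 nM as the sole number. The estimated move is a 1.0-fold higher number from compound 3 to compound 4 (0.01 log units; within the scatter) and no change beyond the scatter is expected. In this assay compound 4 is estimated at 70000 nM with an expected range of 35000 nM to 100000 nM for now.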

Compound 4, half-maximal inhibitory concentration: > 100000 nM
Compound 4 was reported as a limit (the forecaster's own chance of this, stated with the estimate: 35%); at least 1.4-fold (0.15 log units) between middle value and limit.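

In this assay, among these compounds, trifluoromethoxy in place of trifluoromethyl on an aromatic carbon, para to a large group, gives the first step with a readable direction: an at least 1.4-fold higher number from compound 3 to compound 4 (0.16 log units; that floor lies within the scatter). Going by these compounds, compound 4 is a limit of the assay and not a number, so this step has only a floor, and its true size stays unknown. Among the compounds shown here, the exchange therefore brings no gain at this position, and compound 3 remains the only compound with a number, while the others gather at one limit: the limit of > 100000 nM in this assay, at which 3 of the 4 values shown sit.

The compounds shown leave open whether a nitrile or an amine on the same aromatic carbon would give a number or a limit in this assay. They also leave open how far compound 4 truly lies from compound 3.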